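Adding a Methyl Group to an Aryl-Amine Nicotinic Ligand

The compounds below may be only part of what the source reports. "The series", "measured", "known", "first", "only" and "open" are said of these compounds alone.

Measured compounds:
- compound 1 `c1ccc(Nc2ccc(N3CC4CC(C3)N4)cn2)cc1`: 2.66 nM
- compound 2 `Cc1ccc(Nc2ccc(N3CC4CC(C3)N4)nn2)cc1`: 44.3 nM

In an assay on cell membranes for displacement of a labelled ligand from Neuronal acetylcholine receptor; alpha4/beta2 (Rattus norvegicus) (on this read-out higher numbers stand for weaker inhibition and lower numbers for stronger inhibition), compound 1 gives the lower of the two numbers, and compound 2 gives a number far above it, well beyond the scatter. Compound 2 differs from compound 1 in more than one place, so what those two values show cannot be tied to a single change. Compound 3 `Cc1ccc(Nc2ccc(N3CC4CC(C3)N4)cn2)cc1` differs from compound 1 in one place only: methyl in place of hydrogen on an aromatic carbon, which reads at the next bond out as phenyl to 4-methylphenyl. With no single-change comparison to lean on, a small step is expected, likely within the scatter. Compound 3 is expected to give 4 nM, between 1.5 nM and 12 nM. The expected step of a 1.5-fold higher number from compound 1 to compound 3 (0.18 log units; within the scatter) is therefore modest, with no firm direction.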

Compound 3, inhibition constant: 52.1 nM
Compound 3: the middle estimate sits 13-fold (1.11 log units) below what was measured; measured number outside the range, above it.
By their numbers in this assay, from the lowest: compound 1; then compounds 2 and 3 (each within the scatter of the next).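

In this assay, going from phenyl to 4-methylphenyl gives a 20-fold higher number from compound 1 to compound 3 (1.29 log units; beyond the scatter) and so weaker inhibition. This position is therefore sensitive: one added carbon, with no hydrogen-bond donor or acceptor and no net charge, moves the number well beyond the scatter. No measurement at hand explains this.

On these data alone, whether any group at this place would weaken inhibition, or methyl in particular, stays open. A fluorine atom, a methoxy group or an amine in the same place could begin to settle that.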